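Ethoxycarbonyl to carboxy: a change without precedent in the series

The source may report more compounds than this note shows. Statements on the series, on what has been measured and on what is new or still open speak of the compounds shown alone.

Three measured compounds share one core and differ only in the group on the carbonyl carbon of the amide. Compound 1 `CCOC(=O)c1sc(-c2cccc(NC(=O)c3ccc(F)cc3)c2)nc1Nc1ccc(N2CCN(C)CC2)cc1` gives 3.53% in a functional assay on Ramos cells (Homo sapiens) for antiproliferative activity, read by CCK-8 assay, with a stated time of 72 h, tested at 40 uM; a higher number here means more inhibition at the concentration tested (going by the name of the read-out), a lower number less inhibition. Compound 2 `CCOC(=O)c1sc(-c2cccc(NC(=O)c3ccccc3F)c2)nc1Nc1ccc(N2CCN(C)CC2)cc1` gives 96.4% in this assay, the highest of the three numbers, and compound 3 `CCOC(=O)c1sc(-c2cccc(NC(=O)[C@H]3CC[C@H](C)CC3)c2)nc1Nc1ccc(N2CCN(C)CC2)cc1` gives 19.9%. The steps are a number 92.9 percentage points higher from compound 1 to compound 2 (beyond the scatter), a number 16.4 percentage points higher from compound 1 to compound 3 (beyond the scatter) and a number 76.5 percentage points lower from compound 2 to compound 3 (beyond the scatter); all three lie beyond the scatter, so the read-out answers strongly to what sits on the carbonyl carbon.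

Compound 4 `CN1CCN(c2ccc(Nc3nc(-c4cccc(NC(=O)c5ccccc5F)c4)sc3C(=O)O)cc2)CC1` keeps the 2-fluorophenyl of compound 2 and changes elsewhere: hydrogen in place of ethyl on an oxygen next to a carbonyl group. No measured step touches the ethyl of the ethoxycarbonyl; every step shown concerns the amide, so none bears on this change and there is no measured size to lean on. The expectation is therefore held wide, with the direction a guess rather than an inference. Compound 4 is expected to give 40% in this assay, within 5% to 90%, and the expected step is a number 56.4 percentage points lower from compound 2 to compound 4 (beyond the scatter).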

Compound 4, a percentage reported as inhibition, at one concentration (the size of the read-out at that concentration, not a potency): 93.4%
For compound 4 the middle estimate is 53.4 percentage points below the measured one; the whole stated range lies below it.
By their numbers in this assay, from the lowest: compound 1; then compound 3; then compounds 4 and 2 (each within the scatter of the next).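

The change of ethoxycarbonyl to carboxy is the first shown away from the amide, and with the 2-fluorophenyl held on the carbonyl carbon it gives a number 3 percentage points lower from compound 2 to compound 4 (within the scatter) in this assay. At this oxygen, then, hydrogen in place of ethyl leaves the read-out within the scatter, while each step on the amide among compound 1, compound 2 and compound 3 lies beyond it. Nothing measured here gives a reason for this result.

The compounds shown leave open whether the same change holds with the 4-fluorophenyl of compound 1 or the 4-methylcyclohexyl of compound 3 on the carbonyl carbon, where the numbers are far lower. They also leave open how a primary carboxamide or a propyl ester would read at this place.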